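Amide Variation on a Shared Trimethoxyphenyl Core

The compounds below may be only part of what the source reports. "The series", "measured", "known", "first", "only" and "open" are said of these compounds alone.

Measured so far:
compound 1, `COc1ccc(CN(C(=O)C2CC2)c2cc(OC)c(OC)c(OC)c2)cc1O`, 59 nM
compound 2, `COc1ccc(CN(C(C)=O)c2cc(OC)c(OC)c(OC)c2)cc1O`, 79 nM
compound 3, `COc1ccc(CN(C(=O)/C=C/CBr)c2cc(OC)c(OC)c(OC)c2)cc1O`, 71 nM

In a functional assay on MGC-803 cells (Homo sapiens) for inhibition, read by MTT assay, with a stated time of 48 h (a lower number here means a stronger inhibitor, a higher number a weaker inhibitor), compound 3 gives 71 nM, the second highest of the three numbers; its nearest neighbour is compound 2 and its furthest is compound 1, and both gaps lie within the scatter. Compound 4, `COc1ccc(CN(C(=O)C(C)C)c2cc(OC)c(OC)c(OC)c2)cc1O`, is not yet measured. It differs from compound 3 at the carbonyl carbon: isopropyl in place of 3-bromoprop-1-en-1-yl on a carbonyl carbon.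

Among the compounds with values here, three measured steps bear on this change, since each of them also swaps the group on that carbonyl carbon. They read a 1.3-fold higher number from compound 1 to compound 2 (0.13 log units; within the scatter), a 1.2-fold higher number from compound 1 to compound 3 (0.08 log units; within the scatter) and a 1.1-fold lower number from compound 2 to compound 3 (0.05 log units; within the scatter), every one within the scatter. Since cyclopropyl, methyl and 3-bromoprop-1-en-1-yl give numbers so close to one another on this core, the arrival of isopropyl is expected to leave this assay essentially unchanged, with no step beyond the scatter in either direction. The expected step is a 1.1-fold lower number from compound 3 to compound 4 (0.04 log units; within the scatter). Compound 4 is therefore estimated at 65 nM, within a range from 35 nM to 125 nM.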

Compound 4, half-maximal inhibitory concentration: 210 nM
Beside the measured number, compound 4's estimate is 3.2-fold (0.51 log units) below it, and the stated range ends below it.
By their numbers in this assay, from the lowest: compounds 1, 3 and 2 (each within the scatter of the next); then compound 4.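

In this assay, the group on this carbonyl carbon proved not to be interchangeable: the assay gives a 3.0-fold higher number from compound 3 to compound 4 (0.47 log units; beyond the scatter) and a 2.7-fold higher number from compound 2 to compound 4 (0.42 log units; beyond the scatter) and a 3.6-fold higher number from compound 1 to compound 4 (0.55 log units; beyond the scatter), all beyond the scatter, while cyclopropyl, methyl and 3-bromoprop-1-en-1-yl had stayed within the scatter of one another. Compound 4 is therefore the weakest of the four, and isopropyl is the only group shown that sets a compound apart at this position. No available evidence accounts for this loss of activity.

The compounds shown leave open whether the loss is particular to isopropyl or also appears with tert-butyl on the same carbonyl carbon. They also leave open whether an amine or a longer chain such as n-butyl there would match compound 1, compound 2 and compound 3 or fall with compound 4.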